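This account rests on a few compounds, and the source may have more. Where it says the series, first, only, none or still open, it means among the compounds named here.

Measured so far in a functional assay on the whole organism for inhibition, with Rattus norvegicus as the target; a higher number here means that more compound is needed for the effect, a lower number that less compound is needed: compound 1 `CC1CC/C(=N\Nc2ccc(Br)cc2)c2ncc(C(=O)O)c(=O)n21` gives 0.8 umol/kg; compound 2 `CC1CC/C(=N\Nc2ccc([N+](=O)[O-])cc2)c2ncc(C(=O)O)c(=O)n21` gives 0.8 umol/kg; compound 3 `CC(C)c1ccc(N/N=C2\CCC(C)n3c2ncc(C(=O)O)c3=O)cc1` gives 2.4 umol/kg.

Compound 3 stands highest of the three numbers in this assay, with a 3.0-fold higher number from compound 1 to compound 3 (0.48 log units; beyond the scatter) and a 3.0-fold higher number from compound 2 to compound 3 (0.48 log units; beyond the scatter) as its steps to the others, while no change at the digits printed from compound 1 to compound 2 (within the scatter) shows no difference. Compound 4 `CC1CC/C(=N\Nc2ccc(-c3ccccc3)cc2)c2ncc(C(=O)O)c(=O)n21` is not yet measured; against compound 3 the change is phenyl in place of isopropyl on an aromatic carbon. Among the compounds with values here, no measured step carries a phenyl at this position, so none bears on the change directly; the steps to compound 3 only show that isopropyl at this aromatic carbon raises the number modestly relative to bromo or nitro. Phenyl, also without donors or acceptors, is expected to sit near compound 3, with no change at the digits printed from compound 3 to compound 4 (within the scatter) expected to stay within the scatter. For compound 4 in this assay the estimate is 2.4 umol/kg, range 0.8 umol/kg to 7.2 umol/kg.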

Compound 4, dose for 50% inhibition: 1.1 umol/kg
Compound 4: middle estimate off by 2.2-fold (0.34 log units), on the high side, within the range that was stated.
By their numbers in this assay, from the lowest: compounds 1, 2 and 4 (each within the scatter of the next); then compound 3.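

Phenyl, with more heavy atoms than isopropyl, does not push the number further up in this assay (a 2.2-fold lower number from compound 3 to compound 4 (0.34 log units; beyond the scatter)), so group size as counted here does not track the number across compound 3 and compound 4. Phenyl also stays within the scatter of the earlier groups at this aromatic carbon (a 1.4-fold higher number from compound 2 to compound 4 (0.14 log units; within the scatter); a 1.4-fold higher number from compound 1 to compound 4 (0.14 log units; within the scatter)), leaving isopropyl as the only group set apart. On these data alone, whether that holds for other alkyl groups, such as methyl or tert-butyl, stays open, as does the outcome with an amine or a carboxylic acid here. Nothing measured gives a reason for the step from isopropyl to phenyl.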